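A Fourth Aromatic Group on the Shared Core

This account rests on a few compounds, and the source may have more. Where it says the series, first, only, none or still open, it means among the compounds named here.

Three compounds sharing one core were measured in an ADME assay on microsomes from liver (Mus musculus) for metabolic stability, read by LC-MS, with a stated time of 30 min, tested at 1 uM; a higher number here means that more of the compound is left, a lower number that less of the compound is left. Compound 1 `O=C(NCc1ccc(S(=O)(=O)N2CCCCC2)cc1)c1ccn2cncc2c1` gives 1%. Compound 2 `O=C(NCc1ccc(S(=O)(=O)N2CCCCC2)cc1)c1cc2ccncc2o1` gives 0.14%. Compound 3 `O=C(NCc1ccc(S(=O)(=O)N2CCCCC2)cc1)c1cc2cnccc2o1` gives 4.6%, the highest of the three numbers, though its gaps to compound 1 and to compound 2 both lie within the scatter. The steps among the three are all small: a number 0.9 percentage points lower from compound 1 to compound 2 (within the scatter), a number 3.6 percentage points higher from compound 1 to compound 3 (within the scatter) and a number 4.5 percentage points higher from compound 2 to compound 3 (within the scatter).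

Compound 4 `O=C(NCc1ccc(S(=O)(=O)N2CCCCC2)cc1)c1ccc2nc[nH]c2c1` carries a different group on the carbonyl carbon: a group of 9 heavy atoms (7 carbon, 2 nitrogen; one five-membered aromatic ring with 2 hetero atoms, one six-membered aromatic ring of carbon only) in place of a group of 9 heavy atoms (7 carbon, 1 nitrogen, 1 oxygen; one five-membered aromatic ring with 1 hetero atom, one six-membered aromatic ring with 1 hetero atom), on a carbonyl carbon. Compound 1 also carries a five-membered aromatic ring with 2 hetero atoms on that carbon, so the step of a number 3.6 percentage points higher from compound 1 to compound 3 (within the scatter) is the closest comparison, and it lay within the scatter. Every exchange of the group on the carbonyl carbon seen here stayed within the scatter, and all three values are very low. Compound 4 is therefore expected to stay close to the measured compounds, with an expected step of a number 1.6 percentage points lower from compound 3 to compound 4 (within the scatter) that does not reach beyond the scatter. The estimate for compound 4 is 3%, with a range from 0.3% to 15%.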

Compound 4, percent of the compound remaining: 16%
Estimate against measurement, compound 4: 13 percentage points below, and the stated range ends below it.
By their numbers in this assay, from the lowest: compounds 2, 1 and 3 (each within the scatter of the next); then compound 4.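

In this assay, the group on the carbonyl carbon proved able to shift the number beyond the scatter, which no exchange among the first three compounds had done: 1H-benzimidazol-6-yl gives a number 11.4 percentage points higher from compound 3 to compound 4 (beyond the scatter), a number 15.9 percentage points higher from compound 2 to compound 4 (beyond the scatter) and a number 15 percentage points higher from compound 1 to compound 4 (beyond the scatter). The last of these steps shows that a five-membered aromatic ring with 2 hetero atoms does not by itself set the result, since both groups carry such a ring and the same count of heavy atoms, while only the group in compound 4 has a six-membered aromatic ring of carbon only. Nothing available explains why this exchange raises the number.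

The compounds shown do not separate the carbon-only six-membered ring from the hydrogen-bond donor that 1H-benzimidazol-6-yl brings in place of the group in compound 3, a question that a methyl group in place of the hydrogen on the ring nitrogen could address. They also leave open whether a fluorine or a methoxy group on the 1H-benzimidazol-6-yl group would lift the number further, as compound 4 still stands at only 16%.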